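This account rests on a few compounds, and the source may have more. Where it says the series, first, only, none or still open, it means among the compounds named here.

Going by the values given here, in a functional assay on MCF7 cells (Homo sapiens) for cytotoxicity, read by LDH release, with a stated time of 48 h (a lower number here means a stronger inhibitor, a higher number a weaker inhibitor), compound 1 (`Cn1cnc(C(=O)NNC(=O)COc2ccc(C(=O)c3ccccc3)cc2)c1`) gives 31600 nM and lies within the scatter of the only other measured compound. Compound 2 (`Cc1ccc(C(=O)c2cc(F)c(OCC(=O)NNC(=O)c3ccc(=O)oc3)c(Cl)c2)cc1`) gives 24200 nM and cannot be separated from compound 1 on these numbers. Among the compounds with values here, the change from compound 1 to compound 3 (`O=C(COc1ccc(C(=O)c2ccccc2)cc1)NNC(=O)c1ccc(=O)oc1`) is a group of 7 heavy atoms (5 carbon, 2 oxygen; one six-membered aromatic ring with 1 hetero atom) in place of a group of 6 heavy atoms (4 carbon, 2 nitrogen; one five-membered aromatic ring with 2 hetero atoms), on a carbonyl carbon on a carbonyl carbon whose other neighbours are an amide-type nitrogen, and compound 3 has no measurement yet. Within the data shown here, no step between measured compounds is available, so the only guide is compound 2, which carries the entering group on a different core and gives 24200 nM in this assay without leaving the scatter of compound 1. The estimated step of a 1.1-fold lower number from compound 1 to compound 3 (0.05 log units; within the scatter) is therefore expected to stay within the scatter, in neither direction. For compound 3 the estimate is 28000 nM with an expected range from 12000 nM to 62000 nM for the coming measurement.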

Compound 3, half-maximal inhibitory concentration: 61100 nM
For compound 3 the middle estimate is 2.2-fold (0.34 log units) below the measured one; measured number inside the range.
By their numbers in this assay, from the lowest: compounds 2, 1 and 3 (each within the scatter of the next, the first and the last beyond it).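

In this assay, placing the six-membered aromatic ring with 1 hetero atom in place of 1-methyl-1H-imidazol-4-yl, on a carbonyl carbon whose other neighbours are an amide-type nitrogen, gives a 1.9-fold higher number from compound 1 to compound 3 (0.29 log units; within the scatter) on the shared core. Going by these compounds alone, this is the first reading at this position with only one place changed, and it stays within the scatter, so the two groups cannot be separated here. No measurement on hand bears on the reason for this result.

Open, as far as these compounds go, is whether a plain phenyl group or a short chain ending in a carboxylic acid on this carbonyl carbon would give a step beyond the scatter. Also open, from the compounds shown here alone, is what the fluorine, chlorine and methyl groups of compound 2 each contribute on their own.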